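Replacing 2,6-dichlorophenyl with 1-methyl-1H-imidazol-2-yl

The source may hold more compounds than are shown below. What is called first, only, known or untested is meant among the compounds shown, and "the series" means these compounds.

Among the compounds with values here, in a functional assay for inhibition, with Homo sapiens as the target (on this read-out lower numbers stand for stronger inhibition and higher numbers for weaker inhibition), two compounds have numbers so far. Compound 1 (`COc1cc(OC)c(C(=O)/C=C/c2c(Cl)cccc2Cl)c(OC)c1`) stands at 1090 nM and compound 2 (`COc1cc(OC)c(C(=O)/C=C/c2ccc3ccccc3c2)c(OC)c1`) at 2150 nM on this read-out, and these two values lie within the scatter of each other, so neither can be ranked ahead. Compound 3 (`COc1cc(OC)c(C(=O)/C=C/c2nccn2C)c(OC)c1`) keeps the core of compound 1 but carries 1-methyl-1H-imidazol-2-yl in place of 2,6-dichlorophenyl on a double-bonded chain carbon bound to a double-bonded chain carbon. Within the data shown here, no measured pair differing in one place is available to size this change, so what follows is a judgement with wide margins. In this assay the expected change is a 4.1-fold higher number from compound 1 to compound 3 (0.62 log units; beyond the scatter) toward weaker inhibition, a step beyond the scatter. For compound 3 the estimated value is 4500 nM with an expected range from 1200 nM to 15000 nM in this measurement.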

Compound 3, half-maximal inhibitory concentration: 3800 nM
Compound 3: middle estimate off by 1.2-fold (0.07 log units), on the high side, and the stated range covers the measured number.
By their numbers in this assay, from the lowest: compounds 1, 2 and 3 (each within the scatter of the next, the first and the last beyond it).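

In this assay, putting 1-methyl-1H-imidazol-2-yl in place of 2,6-dichlorophenyl on a double-bonded chain carbon bound to a double-bonded chain carbon gives a 3.5-fold higher number from compound 1 to compound 3 (0.54 log units; beyond the scatter). Within the data shown here, this is the first step that sizes a single change at this position, and it shows that the change weakens inhibition by a modest step while leaving a measurable value. The swap takes out a six-membered aromatic ring of carbon only and both chlorine atoms, brings in a five-membered aromatic ring with 2 hetero atoms, and no measurement at hand accounts for the step.

The compounds shown leave open whether the step follows the change of ring or the loss of chlorine, which an unsubstituted phenyl at this place could help separate. They also leave open what a pyridyl group or an imidazolyl group without the methyl would give on the same core.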